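The source may report more compounds than this note shows. Statements on the series, on what has been measured and on what is new or still open speak of the compounds shown alone.

The measured compounds:

compound 1, `CC(=O)c1c(C)nc2c(OCc3ccccc3)cccn12`: in a functional assay on the whole organism with Rattus norvegicus as the target, with a stated time of 4 h, at a dose of 40 mg/kg by the intraperitoneal route (on this read-out higher numbers stand for more inhibition at the one dose given (going by the name of the read-out) and lower numbers for less inhibition), compound 1 gives 57%
compound 2, `Cc1nc2c(OCc3ccccc3)cccn2c1CCC#N`: in this assay compound 2 gives 40%

Compound 1 holds the higher of these two numbers. Its nearest neighbour is compound 2, reached by a single change on an aromatic carbon of the shared core, and that step is a number 17 percentage points lower from compound 1 to compound 2 (beyond the scatter).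

Compound 3, `Cc1nc2c(OCc3ccccc3)cccn2c1CS(C)(=O)=O`, is not yet measured. It differs from compound 1 in one place: (methylsulfonyl)methyl in place of acetyl on an aromatic carbon.

Going by the values given here, only one measured step bears on this change. It replaced the same acetyl group at the same aromatic carbon with a 2-cyanoethyl group and gave a number 17 percentage points lower from compound 1 to compound 2 (beyond the scatter). A second replacement of that acetyl group is therefore expected to lower the number by a modest amount too, about as much as that step, so the estimated step is a number 15 percentage points lower from compound 1 to compound 3 (beyond the scatter). Compound 3 is expected to give about 42% in this assay, somewhere between 22% and 62%.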

Compound 3, a percentage reported as inhibition, in the whole organism at one dose (the size of the read-out at that dose, not a potency): 61%
Compound 3: the middle estimate sits 19 percentage points below what was measured, within the range that was stated.
By their numbers in this assay, from the lowest: compound 2; then compounds 1 and 3 (each within the scatter of the next).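

Replacing the acetyl group at this aromatic carbon need not lower the number in this assay: putting (methylsulfonyl)methyl there gives a number 4 percentage points higher from compound 1 to compound 3 (within the scatter), so the drop seen with 2-cyanoethyl does not follow from losing acetyl alone. What enters makes the difference among these compounds, as the two replacements stand apart, with a number 21 percentage points higher from compound 2 to compound 3 (beyond the scatter). Nothing measured here accounts for that gap.

The compounds shown leave open whether an amine or a carboxylic acid on this same carbon would keep the number where the (methylsulfonyl)methyl group keeps it, and whether a longer chain carrying the methylsulfonyl group would do so too. Each number also comes from a single dose, so it gives the size of the effect at that dose and not a potency.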